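Anilino in place of benzylamino on a shared chloropyrimidine core

A few compounds are considered here, and "the series" means these few. Any claim that something is new, unique, unknown or untested is made for them only; others in the source may bear on it.

Measured so far:
compound 1 `CCN1CCN(c2ccc(Nc3ncc(Cl)c(Nc4ccccc4C)n3)cc2)CC1`: 2060 nM
compound 2 `COc1ccccc1CNc1nc(Nc2ccc(N3CCN(C)CC3)cn2)ncc1Cl`: 10800 nM

Of the compounds shown here, two have been tested in a functional assay on Jurkat cells (Homo sapiens) for inhibition, read by CCK-8 assay, with a stated time of 48 h; on this read-out higher numbers stand for weaker inhibition of growth and lower numbers for stronger inhibition of growth. Compound 1 gives 2060 nM in this assay, while compound 2 gives 10800 nM, the highest of the two numbers and therefore the weaker growth inhibitor; the gap between the two values is beyond the usual scatter.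

Compound 3 `COc1ccc(Nc2nc(Nc3ccc(N4CCN(C)CC4)cn3)ncc2Cl)cc1` has not yet been measured. It differs from compound 2 in one place only: 4-methoxyphenyl in place of 2-methoxybenzyl on a nitrogen on an aromatic ring. The rest of the molecule, including the shared core and the other amine substituent, stays unchanged.

For the measured compounds named here, no directly comparable single step exists among the measured pair, so the expectation rests on the numbers themselves. Compound 1, which also carries an aryl group rather than a benzyl group on the corresponding nitrogen, gives 2060 nM. On that basis compound 3 is expected to show a lower number than compound 2, a step of a 3.1-fold lower number from compound 2 to compound 3 (0.49 log units; beyond the scatter), and its estimated value in this assay is 3500 nM, with a range from 1000 nM to 12000 nM.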

Compound 3, concentration for 50% growth inhibition: 11200 nM
Beside the measured number, compound 3's estimate is 3.2-fold (0.51 log units) below it; the range from low to high includes it.
By their numbers in this assay, from the lowest: compound 1; then compounds 2 and 3 (each within the scatter of the next).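

In this assay, putting 4-methoxyphenyl in place of 2-methoxybenzyl on this nitrogen gives a 1.0-fold higher number from compound 2 to compound 3 (0.02 log units; within the scatter), so compound 2 and compound 3 cannot be told apart on this read-out. For the compounds shown here, this is the first comparison that changes only this one place, and it shows that, for this pair, going from (2-methoxybenzyl)amino to (4-methoxyphenyl)amino leaves the growth-inhibition number level, even though the swap alters both the group on the nitrogen and the numbered location of the methoxy group on the ring. Nothing measured here explains why the two compounds match.

Because both features change in the same step, the compounds shown leave open what each contributes alone, which a 2-methoxyphenyl or a 4-methoxybenzyl group at this nitrogen would separate. They also leave open whether this place responds at all to groups of another kind, such as an unsubstituted phenyl, a ring carrying a carboxylic acid or an amine, or a longer chain between the nitrogen and the ring.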